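The source may hold more compounds than are shown below. What is called first, only, known or untested is meant among the compounds shown, and "the series" means these compounds.

Compound 1 `Nc1cc(N)c2nc(-c3ccccc3)c(Oc3ccc(F)cc3)nc2c1` carries two amino groups on its core together with a phenyl group and a 4-fluorophenoxy group. In a functional assay on SK-MEL-5 cells (Homo sapiens) for inhibition, read by sulforhodamine B assay, with a stated time of 48 h (on this read-out lower numbers stand for higher toxicity in this test and higher numbers for lower toxicity in this test), compound 1 gives 83200 nM, the highest of the two numbers measured here. Compound 2 `COc1cc(CNc2nc3cc(N)cc(N)c3nc2-c2ccccc2)cc(OC)c1OC` gives 29500 nM in this assay, a lower number that lies beyond the usual scatter. For compound 3 `CCOC(=O)[C@H](CCC(=O)O)NC(=O)c1ccc(Oc2nc3cc(N)cc(N)c3nc2-c2ccccc2)cc1` this assay reports only a limit, < 100000 nM, and not a number. Compound 4 `Nc1cc(N)c2nc(-c3ccccc3)c(NCc3ccc(F)cc3)nc2c1` has not yet been measured; it differs from compound 1 in one place: (4-fluorobenzyl)amino in place of 4-fluorophenoxy on an aromatic carbon. Among the measured compounds shown here, no pair of measured compounds differs in a single place, so the size of this step cannot be read from the data and can only be expected. Because compound 2, whose core also bears a substituent joined through nitrogen rather than oxygen, gives 29500 nM, a lower number than compound 1 is expected for compound 4. The expected step is a 2.1-fold lower number from compound 1 to compound 4 (0.32 log units; beyond the scatter). Compound 4 is estimated to give about 40000 nM, with a likely range from 15000 nM to 90000 nM.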

Compound 4, concentration lethal to 50% of the cells: 6920 nM
Compound 4: the middle estimate sits 5.8-fold (0.76 log units) above what was measured; measured number outside the range, below it.
By their numbers in this assay, from the lowest: compound 4; then compound 2; then compound 1.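

Replacing 4-fluorophenoxy with (4-fluorobenzyl)amino on this aromatic carbon, next to the ring nitrogen and ortho to a phenyl group, gives a 12-fold lower number from compound 1 to compound 4 (1.08 log units; beyond the scatter) in this assay, so toxicity in this test is highly sensitive to the group at this position. The change is not a single one, however: nitrogen takes the place of oxygen, the group gains carbon, and a hydrogen-bond donor enters. Nothing measured here explains the size of this step.

The compounds shown leave open which of these differences accounts for the step. A phenylamino group, which has the nitrogen without the added carbon, and a benzyloxy group, which has the added carbon but retains the oxygen, would begin to separate them.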